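Adding an oxolan-3-yl group to an inactive compound

This account rests on a few compounds, and the source may have more. Where it says the series, first, only, none or still open, it means among the compounds named here.

- Compound 1 `COc1ccc(/C=C/C(=O)Nc2cc3c(Nc4ccc(F)c(Cl)c4)ncnc3cc2O[C@H]2CCOC2)c(OC)c1` gives 2760 nM
- Compound 2 `COc1cc(/C=C/C(=O)Nc2cc3c(Nc4ccc(F)c(Cl)c4)ncnc3cc2OC)cc(OC)c1` gives "not active" (no number reported)

In a functional assay on PC-3 cells (Homo sapiens) for cytotoxicity, read by MTT assay, with a stated time of 72 h (a higher number here means a weaker inhibitor, a lower number a stronger inhibitor), compound 2 is reported as "not active" (no number reported) and so has no single number. Compound 3 `COc1cc(/C=C/C(=O)Nc2cc3c(Nc4ccc(F)c(Cl)c4)ncnc3cc2O[C@H]2CCOC2)cc(OC)c1` differs from it by one change. The change oxolan-3-yl in place of methyl on an oxygen on an aromatic ring puts oxolan-3-yl in place of methyl on an oxygen on an aromatic ring. Going by the values given here, no measured pair shows this change alone. Compound 1 also carries oxolan-3-yl and gives 2760 nM in this assay and this suggests an expected step from no reported activity towards a weak but measurable value. For compound 3 the expected value is 5000 nM (estimated range 1500 nM to 20000 nM).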

Compound 3, half-maximal inhibitory concentration: 25600 nM
Compound 3: the middle estimate sits 5.1-fold (0.71 log units) below what was measured, and the stated range ends below it.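

In this assay compound 3 gives 25600 nM as a real number, so oxolan-3-yl in place of methyl on the oxygen goes with measurable activity in a compound carrying 3,5-dimethoxyphenyl, where compound 2 is reported as not active. Yet 3,5-dimethoxyphenyl in place of 2,4-dimethoxyphenyl gives a 9.3-fold higher number from compound 1 to compound 3 (0.97 log units; beyond the scatter) and so oxolan-3-yl does not set the value alone. Nothing measured here explains either result. As far as these compounds go, whether a longer chain ending in an amine on this oxygen would lower the number in this assay remains open.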